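The source may report more compounds than this note shows. Statements on the series, on what has been measured and on what is new or still open speak of the compounds shown alone.

Measured compounds:
- compound 1, `COC(=O)[C@@]1(C)CC[C@@H]2C3=C1CC[C@@H](C)[C@]3(C)C[C@@H]1c3cc(C)ccc3N[C@H]21`: 15000 nM
- compound 2, `COC(=O)[C@@]1(C)CC[C@@H]2C3=C1CC[C@@H](C)[C@]3(C)C[C@@H]1c3cc(Br)ccc3N[C@H]21`: 34000 nM
- compound 3, `COC(=O)[C@@]1(C)CC[C@@H]2C3=C1CC[C@@H](C)[C@]3(C)C[C@@H]1c3cc(Cl)ccc3N[C@H]21`: 28000 nM

All three share one core and differ only in the group on the aromatic carbon of the six-membered carbon ring. In a functional assay on HBL-100 cells (Homo sapiens) for inhibition, read by sulforhodamine B assay, with a stated time of 48 h (a higher number here means a weaker inhibitor of growth, a lower number a stronger inhibitor of growth), compound 3 gives 28000 nM; its number lies between those of compound 2 and compound 1, and in this assay both neighbours are within the usual scatter of it, so no order among the three can be read from it. Among the compounds with values here, the one step that goes beyond the scatter is a 2.3-fold higher number from compound 1 to compound 2 (0.36 log units; beyond the scatter).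

Compound 4, `COC(=O)[C@@]1(C)CC[C@@H]2C3=C1CC[C@@H](C)[C@]3(C)C[C@@H]1c3cc(F)ccc3N[C@H]21`, is not yet measured. It differs from compound 3 by fluoro in place of chloro on an aromatic carbon. Within the data shown here, the steps that bear on this swap are the earlier exchanges at the same carbon: a 1.2-fold lower number from compound 2 to compound 3 (0.08 log units; within the scatter) and a 1.9-fold higher number from compound 1 to compound 3 (0.27 log units; within the scatter). Both stayed within the scatter, so for compound 4 the step of a 1.3-fold lower number from compound 3 to compound 4 (0.10 log units; within the scatter) is expected to be small as well, with no clear direction. Compound 4 is therefore estimated at 22000 nM in this assay, within a range from 9000 nM to 50000 nM.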

Compound 4, concentration for 50% growth inhibition: 18000 nM
The estimate for compound 4 lay 1.2-fold (0.09 log units) above the measured number; low and high end bracket the measured number.
By their numbers in this assay, from the lowest: compounds 1, 4, 3 and 2 (each within the scatter of the next, the first and the last beyond it).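

In this assay, fluoro at this aromatic carbon stays within the scatter of each of the other three groups: a 1.6-fold lower number from compound 3 to compound 4 (0.19 log units; within the scatter) against chloro, a 1.9-fold lower number from compound 2 to compound 4 (0.28 log units; within the scatter) against bromo and a 1.2-fold higher number from compound 1 to compound 4 (0.08 log units; within the scatter) against methyl. Fluoro therefore cannot be told apart from any of them, and the gap between compound 1 and compound 2 remains the only one beyond the scatter at this position, with compound 3 and compound 4 each within the scatter of both ends. Nothing measured here explains how close these numbers lie.

From the compounds shown here alone, only methyl and three halogens appear at this carbon, so the effect of an amine, a methoxy group or a carboxylic acid there remains open. Also open, going by these compounds, is whether any change elsewhere on the shared core, such as to the methyl ester, would shift these numbers.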